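Chlorine moved on the benzyl ring of a cytotoxic scaffold

A few compounds are considered here, and "the series" means these few. Any claim that something is new, unique, unknown or untested is made for them only; others in the source may bear on it.

Measured so far:
compound 1, `Cc1ccc(/C=C2\CN(C(=S)SCc3cn(Cc4ccccc4F)nn3)C/C(=C\c3ccc(C)cc3)C2=O)cc1`, 91500 nM
compound 2, `COc1ccc(/C=C2\CN(Cc3cn(Cc4cccc(Cl)c4)nn3)C/C(=C\c3ccc(OC)cc3)C2=O)cc1`, 98000 nM

Two compounds share a core in which the nitrogen carries a substituted benzyl-type arm through a five-membered aromatic ring, and both were tested in a functional assay on MDA-MB-231 cells (Homo sapiens) for cytotoxicity, read by MTT assay, with a stated time of 24 h; on this read-out higher numbers stand for weaker inhibition and lower numbers for stronger inhibition. Compound 1 gives 91500 nM. For the measured compounds named here, compound 2, the one this account follows, gives 98000 nM in this assay; the number for compound 1 lies within the scatter of it, so the two compounds cannot be told apart on these data, and no step between them is given.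

Compound 3, `COc1ccc(/C=C2\CN(Cc3cn(Cc4ccccc4Cl)nn3)C/C(=C\c3ccc(OC)cc3)C2=O)cc1`, has not yet been tested. It differs from compound 2 in one place: 2-chlorophenyl in place of 3-chlorophenyl on a saturated chain carbon bound to an aromatic nitrogen. The same atoms are present, joined differently, with the chlorine moved on the benzyl ring.

Going by the values given here, with no measured step of this kind to rest on, the change is expected to give a step in this assay of no size beyond the scatter, in no particular direction, so the step of a 1.0-fold lower number from compound 2 to compound 3 (0.01 log units; within the scatter) is expected to be small. Compound 3 is therefore estimated at 95000 nM, within a range from 45000 nM to 200000 nM.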

Compound 3, half-maximal inhibitory concentration: > 100000 nM
Compound 3 ended at the assay's limit (the forecaster's own chance of this, stated with the estimate: 15%); middle value at least 1.0-fold (0.02 log units) away from the limit.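

Compound 3 gives a limit of the assay rather than a number: in this assay compound 3 stands at > 100000 nM. This is the first step shown at this position, on a saturated chain carbon bound to an aromatic nitrogen, and 2-chlorophenyl in place of 3-chlorophenyl gives an at least 1.0-fold higher number from compound 2 to compound 3 (0.00 log units; that floor lies within the scatter). The change therefore brings no stronger inhibition that this read-out can show, but the true size of the step stays unknown because the reading stops at a limit: the limit of > 100000 nM in this assay, at which 1 of the 3 values shown sits.

The compounds shown leave open how far compound 3 lies past that limit, and so whether moving the chlorine matters at all in this assay. They also leave open whether a benzyl ring carrying an amine or a carboxylic acid in place of the chlorine would give a value clearly apart from that of compound 2.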